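This account rests on a few compounds, and the source may have more. Where it says the series, first, only, none or still open, it means among the compounds named here.

Measured compounds:
compound 1 `CC1(C)[C@@H]2CC[C@@]1(C)/C(=N/NC(=O)c1cccs1)C2` — 1030000 nM
compound 2 `CC12C=CC3(O1)C(C(=O)N1CCSC13)C2C(=O)N/N=C1\C[C@H]2CC[C@]1(C)C2(C)C` — "not determined" (no result reported)

Within the data shown here, in an ADME assay on MDCK cells (Canis lupus familiaris) for cytotoxicity, read by MTT assay, with a stated time of 48 h (on this read-out higher numbers stand for lower toxicity in this test and lower numbers for higher toxicity in this test), compound 1 gives 1030000 nM, the only number in this small set. For compound 2 this assay reports "not determined" (no result reported), so no comparison is possible. Compound 3 `CC1(C)[C@@H]2CC[C@@]1(C)/C(=N/NC(=O)C(F)(F)F)C2` differs from compound 1 by trifluoromethyl in place of thiophen-2-yl on a carbonyl carbon. Among the measured compounds shown here, no step between measured compounds is known here, so the change is expected to move the read-out little, in no clear direction and not beyond the usual scatter. Compound 3 is therefore estimated at 1000000 nM, with a range from 400000 nM to 2500000 nM. The expected step is a 1.0-fold lower number from compound 1 to compound 3 (0.01 log units; within the scatter), within the scatter.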

Compound 3, half-maximal cytotoxic concentration: > 1070000 nM
Compound 3: a limit, no number; the forecaster's own chance of this, stated with the estimate: 30%; at least 1.0-fold (0.02 log units) between middle value and limit.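

In this assay compound 3 gives > 1070000 nM, a limit and not a number. At this place on a carbonyl carbon, a group without a ring can thus stand in for the aromatic thiophen-2-yl, and the change reads only as a floor: an at least 1.0-fold higher number from compound 1 to compound 3 (0.01 log units; that floor lies within the scatter). The reading rests on that limit: the limit of > 1070000 nM in this assay, at which 1 of the 3 values shown sits.

On these data alone, the true size of this step stays open. So does whether an amine, a carboxylic acid or a longer chain on this carbonyl carbon would give a lower number.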